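Swapping Methyl for 4-Iodophenyl on a Ring Nitrogen

The compounds below may be only part of what the source reports. "The series", "measured", "known", "first", "only" and "open" are said of these compounds alone.

Measured compounds:
compound 1 `CCCn1c(=O)[nH]c2nc(-c3ccc(S(=O)(=O)N(C)C)cc3)[nH]c2c1=O`: 18.6 nM
compound 2 `CCCn1c(=O)[nH]c2nc(-c3ccc(S(=O)(=O)N4CCN(C)CC4)cc3)[nH]c2c1=O`: 48.2 nM

Both were tested in an assay on CHO cells for displacement of a labelled ligand from adenosine receptor A2b (Homo sapiens), read by scintillation counting, with a stated time of 75 min, in the presence of a further agent that is not named here; on this read-out lower numbers stand for stronger inhibition and higher numbers for weaker inhibition. Compound 2 gives the highest of the two numbers; its nearest neighbour is compound 1. Compound 3 `CCCn1c(=O)[nH]c2nc(-c3ccc(S(=O)(=O)N4CCN(c5ccc(I)cc5)CC4)cc3)[nH]c2c1=O` differs from compound 2 by 4-iodophenyl in place of methyl on an amine nitrogen in a ring. Within the data shown here, only one measured step is available, a 2.6-fold higher number from compound 1 to compound 2 (0.41 log units; beyond the scatter), which also changed the group on the sulfonyl sulfur and was modest; it bears on the new change only loosely, since the new group entering is much larger. A modest rise in the number is therefore expected, a 1.9-fold higher number from compound 2 to compound 3 (0.27 log units; within the scatter), with the direction uncertain. Compound 3 is estimated at 90 nM, in the range 25 nM to 350 nM.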

Compound 3, inhibition constant: 0.159 nM
Compound 3: middle estimate off by 570-fold (2.75 log units), on the high side, outside the stated range (below it).
By their numbers in this assay, from the lowest: compound 3; then compound 1; then compound 2.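

At this amine nitrogen in a ring, this assay shows that the number need not rise when a much larger group enters: 4-iodophenyl in place of methyl gives a 300-fold lower number from compound 2 to compound 3 (2.48 log units; beyond the scatter), which means far stronger inhibition. The earlier step, made on the sulfonyl sulfur, was modest and gave no sign of a change this large at the new position. Nothing measured here explains the gain. As far as these compounds go, it remains open whether the iodine or the benzene ring carries the effect, and phenyl, 4-chlorophenyl or benzyl at this nitrogen would help separate the two.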